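A few compounds are considered here, and "the series" means these few. Any claim that something is new, unique, unknown or untested is made for them only; others in the source may bear on it.

In a functional assay on VCaP cells (Homo sapiens) for antiproliferative activity, read by propidium iodide staining, with a stated time of 96 h (on this read-out lower numbers stand for stronger inhibition and higher numbers for weaker inhibition), compound 1 `CC(O)(CSc1ccc(S(F)(F)(F)(F)F)cc1)C(=O)Nc1ccc(C#N)cc1C(F)(F)F` gives 20500 nM and compound 2 `CC(O)(CSc1cccc(S(F)(F)(F)(F)F)c1)C(=O)Nc1ccc(C#N)cc1C(F)(F)F` gives 30800 nM while compound 3 `CC(O)(CSc1ccc(F)cc1)C(=O)Nc1ccc(S(F)(F)(F)(F)F)cc1` gives 23000 nM on the same read-out. All three numbers lie within the usual scatter of one another, so compound 3 holds no separate place among them, and no two of these compounds differ in one place only. Compound 4 `CC(O)(CSc1ccccc1C(F)(F)F)C(=O)Nc1ccc(S(F)(F)(F)(F)F)cc1` differs from compound 3 by having 2-(trifluoromethyl)phenyl in place of 4-fluorophenyl on a sulfur. With no measured single change to guide the estimate, no step beyond the scatter is expected in either direction in this assay for this change. The expected step (a 1.2-fold lower number from compound 3 to compound 4 (0.06 log units; within the scatter)) is therefore small. Compound 4 is expected at 20000 nM (estimated range 8000 nM to 45000 nM).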

Compound 4, half-maximal inhibitory concentration: 21000 nM
The estimate for compound 4 lay 1.1-fold (0.02 log units) below the measured number; measured number inside the range.
By their numbers in this assay, from the lowest: compounds 1, 4, 3 and 2 (each within the scatter of the next).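

In this assay, among these compounds, 2-(trifluoromethyl)phenyl in place of 4-fluorophenyl on a sulfur gives a 1.1-fold lower number from compound 3 to compound 4 (0.04 log units; within the scatter) as the first single change that can be read in this set. At this position, therefore, going from 7 to 10 heavy atoms in the group on the sulfur shifts the number by no more than the scatter. No measurement shown accounts for this result.

Going by these compounds, only these two phenyl groups are compared at this position, so how a pyridine ring or a phenyl carrying an amine or a carboxylic acid would read stays open. On these data alone, whether the same change would behave alike on the core of compound 1 also stays open.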